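The source may report more compounds than this note shows. Statements on the series, on what has been measured and on what is new or still open speak of the compounds shown alone.

Compound 1 `CS(=O)(=O)N(CC(=O)Nc1ccccc1)c1ccccc1Cl` gives 70 nM; 72.4 nM (2 entries) in a functional assay on HEK293 cells for positive allosteric modulation of metabotropic glutamate receptor 5 (Rattus norvegicus), read by fluorescence and calcium flux; a lower number here means that less compound is needed, a higher number that more compound is needed for the effect. Compound 2 `CC(C(=O)Nc1cccc(Cl)c1)N(c1ccccc1Cl)S(C)(=O)=O` gives 68 nM in this assay, a number that sits within the scatter of the result for compound 1, and compound 2 stands on that single number alone. Compound 3 `CCCC(C(=O)Nc1cccc(Cl)c1)N(c1ccccc1Cl)S(C)(=O)=O` differs from compound 2 by ethyl in place of hydrogen on a saturated chain carbon, two bonds along the chain from a carbonyl carbon and a sulfonamide nitrogen. Among the measured compounds shown here, no measured pair shows this change, so only a small step, if any beyond the scatter, is expected in this assay, a 2.1-fold higher number from compound 2 to compound 3 (0.31 log units; beyond the scatter). Compound 3 is estimated at 140 nM, within 40 nM to 600 nM.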

Compound 3, half-maximal effective concentration: > 10000 nM
Compound 3 ended at the assay's limit; the forecaster's own chance of this, stated with the estimate: 10%; at least 71-fold (1.85 log units) between middle value and limit.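

Ethyl in place of hydrogen on this saturated chain carbon, the same difference as methyl to propyl, gives an at least 140-fold higher number from compound 2 to compound 3 (2.16 log units; beyond the scatter) in this assay, the only step shown at this position. This one change is thus enough to take the compound out of the measurable range. For compound 3 the reading is a limit and not a number, so the full size of the step stays unknown: the limit of > 10000 nM in this assay, at which 1 of the 3 values shown sits.

The compounds shown leave open where between methyl and propyl the loss sets in, as an ethyl group on this carbon stands among none of them. Also open, from the compounds shown here alone, is whether cyclopropyl, or an amine on the chain, would fare the same.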